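Ortho-chloro step in the benzylamide succinimide series

The compounds below may be only part of what the source reports. "The series", "measured", "known", "first", "only" and "open" are said of these compounds alone.

Measured so far:
- compound 2, `CCC(C(=O)NCc1ccccc1)N1C(=O)CCC1=O`: 90.3 mg/kg
- compound 1, `CC(C(=O)NCc1ccccc1Cl)N1C(=O)CCC1=O`: "not determined" (no result reported)

Among the compounds with values here, compound 2, `CCC(C(=O)NCc1ccccc1)N1C(=O)CCC1=O`, is the only member of the set with a number in a functional assay on the whole organism (strain Albino Swiss CD1) with Mus musculus as the target; on this read-out higher numbers stand for an effect only at larger amounts of compound and lower numbers for an effect already at smaller amounts; in this assay compound 2 gives 90.3 mg/kg. Compound 1, `CC(C(=O)NCc1ccccc1Cl)N1C(=O)CCC1=O`, stands as "not determined" (no result reported) in this assay, so it gives no reference point for the step examined here.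

Compound 3, `CCC(C(=O)NCc1ccccc1Cl)N1C(=O)CCC1=O`, differs from compound 2 in one place: chloro in place of hydrogen on an aromatic carbon. Within the data shown here, no step between two measured compounds covers this kind of change, so the expectation rests on the single number of compound 2 alone.

The step from compound 2 to compound 3 in this assay is expected to be small, a 1.5-fold lower number from compound 2 to compound 3 (0.18 log units; within the scatter), tending toward an effect at somewhat smaller amounts but not clearly beyond the scatter. Compound 3 is therefore estimated at 60 mg/kg in this assay, with a range from 25 mg/kg to 150 mg/kg.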

Compound 3, dose for half-maximal effect: 76.4 mg/kg
Compound 3: the middle estimate sits 1.3-fold (0.10 log units) below what was measured, within the range that was stated.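

The change from phenyl to 2-chlorophenyl gives, in this assay, a 1.2-fold lower number from compound 2 to compound 3 (0.07 log units; within the scatter). Within the data shown here, at this aromatic carbon, ortho to a large group, chloro in place of hydrogen therefore leaves no difference that can be told from the scatter, which the single number of compound 2 could not show on its own. Nothing at hand bears on why the step has this size.

As far as these compounds go, compound 1 has no result in this assay, so the step between it and compound 3 cannot be read, and the part played by the chain on the core stays open. Also open, from the compounds shown here alone, is whether fluoro, methoxy or a carboxylic acid on this same carbon, or chloro on another carbon of the aromatic ring, would give a step beyond the scatter.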